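Working notes: from methoxy to nitro

The source may hold more compounds than are shown below. What is called first, only, known or untested is meant among the compounds shown, and "the series" means these compounds.

- compound 1 `CC1=CC[C@@H]([C@@](C)(O)CCCC(C)(C)NC=S)CC1`: > 100000 nM (a limit, not a number)
- compound 2 `COc1ccc(/C=N\NC(=S)NC(C)(C)CCC[C@](C)(O)[C@@H]2CC=C(C)CC2)cc1`: 48500 nM

All values come from a functional assay on UACC-62 cells (Homo sapiens) for cytotoxicity, read by sulforhodamine B assay; on this read-out lower numbers stand for higher toxicity in this test and higher numbers for lower toxicity in this test. In this assay, among the compounds with values here, compound 2 gives 48500 nM, the only actual number so far. Compound 1 reaches only the limit of the assay, at > 100000 nM.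

The next compound to be tested is compound 3 `CC1=CC[C@@H]([C@@](C)(O)CCCC(C)(C)NC(=S)N/N=C\c2ccc([N+](=O)[O-])cc2)CC1`. It differs from compound 2 at a single place: nitro in place of methoxy on an aromatic carbon. Put another way, the 4-methoxyphenyl of compound 2 becomes the 4-nitrophenyl of compound 3.

Within the data shown here, no measured pair tests a change at this place, so the expectation rests on compound 2 at 48500 nM and remains loose. A small step is expected a 1.4-fold lower number from compound 2 to compound 3 (0.14 log units; within the scatter), toward higher toxicity and close to the usual scatter. The estimated value for compound 3 is 35000 nM, with an expected range of 12000 nM to 100000 nM.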

Compound 3, concentration lethal to 50% of the cells: > 100000 nM
Compound 3 was reported as a limit; the forecaster's own chance of this, stated with the estimate: 15%; at least 2.8-fold (0.45 log units) between middle value and limit.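

In this assay, within the data shown here, nitro in place of methoxy on the aromatic carbon gives the first readable step at this place: an at least 2.0-fold higher number from compound 2 to compound 3 (0.31 log units; beyond the scatter), toward lower toxicity in this test. Compound 3 stands at a limit of the assay, > 100000 nM, and not at a number. The group para to the large group therefore matters to this read-out, since the measurable value of compound 2 does not survive the change from 4-methoxyphenyl to 4-nitrophenyl, but the step can be bounded from one side only because the read-out stops there: the limit of > 100000 nM in this assay, at which 2 of the 3 values shown sit.

The compounds shown leave open whether the measurable toxicity of compound 2 is specific to methoxy or would also appear with other groups at this place, such as an amine, a hydroxyl or a chlorine atom. They also leave open how large the step really is, and whether an ethoxy or another longer chain in place of methoxy would move the value in either direction.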